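A few compounds are considered here, and "the series" means these few. Any claim that something is new, unique, unknown or untested is made for them only; others in the source may bear on it.

Compound 3 `Cn1cnnc1SCC(=O)Nc1ccc(-c2nc(-c3ccccc3)c(-c3ccccc3)n2C)cc1` stands highest of the three compounds measured in a functional assay on MCF7 cells (Homo sapiens) for cytotoxicity, read by MTT assay, with a stated time of 24 h, tested at 0.64 ug/mL (a lower number here means a weaker effect, a higher number a stronger effect of the compound at the concentration tested), where compound 3 gives 33.1%. Compound 1 `Cn1c(-c2ccc(NC(=O)CSc3nc4cc(Cl)ccc4o3)cc2)nc(-c2ccccc2)c1-c1ccccc1` gives 2.4%, and compound 2 `Cc1ccc2oc(SCC(=O)Nc3ccc(-c4nc(-c5ccccc5)c(-c5ccccc5)n4C)cc3)nc2c1` gives 1.1%; the step of a number 1.3 percentage points lower from compound 1 to compound 2 (within the scatter) lies within the scatter. The steps of a number 30.7 percentage points higher from compound 1 to compound 3 (beyond the scatter) and a number 32 percentage points higher from compound 2 to compound 3 (beyond the scatter) are both large, and each replaces a benzoxazol-2-yl group on the sulfur with the 4-methyl-4H-1,2,4-triazol-3-yl ring. Compound 4 `Cc1nnc(SCC(=O)Nc2ccc(-c3nc(-c4ccccc4)c(-c4ccccc4)n3C)cc2)s1` differs from compound 3 in this part of the molecule: 5-methyl-1,3,4-thiadiazol-2-yl in place of 4-methyl-4H-1,2,4-triazol-3-yl on a sulfur. For the measured compounds named here, no measured step compares two such five-membered rings with three hetero atoms, so the two large steps show only that the level of compound 3 depends on the group on the sulfur, not how the thiadiazolyl ring will read. The step from compound 3 to compound 4 is therefore expected to be smaller than those, most likely a moderate decrease, a number 15.1 percentage points lower from compound 3 to compound 4 (beyond the scatter). Compound 4 is estimated at 18%, with a range from 2% to 40%.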

Compound 4, a percentage reported as activity, at one concentration (the size of the read-out at that concentration, not a potency): 35.1%
For compound 4 the middle estimate is 17.1 percentage points below the measured one, and the stated range covers the measured number.
By their numbers in this assay, from the lowest: compounds 2 and 1 (each within the scatter of the next); then compounds 3 and 4 (each within the scatter of the next).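

In this assay, 5-methyl-1,3,4-thiadiazol-2-yl in place of 4-methyl-4H-1,2,4-triazol-3-yl on the sulfur gives a number 2 percentage points higher from compound 3 to compound 4 (within the scatter) and so shows that two different five-membered aromatic rings with 3 hetero atoms can read alike at this position. The level of compound 3 is therefore not unique to the triazolyl ring: the thiadiazolyl ring also stands well clear of both benzoxazolyl compounds, with a number 34 percentage points higher from compound 2 to compound 4 (beyond the scatter) and a number 32.7 percentage points higher from compound 1 to compound 4 (beyond the scatter) both large. Among these four compounds, the readings thus fall into two groups by ring type on the sulfur, with no compound going against that split.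

Nothing given explains why these rings read as they do. From the compounds shown here alone, it also remains open how a phenyl or pyridine ring on the sulfur would read, or an amino group in place of the methyl on the thiadiazolyl ring.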